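A few compounds are considered here, and "the series" means these few. Any claim that something is new, unique, unknown or untested is made for them only; others in the source may bear on it.

Of the compounds shown here, three built on one shared core have been tested in a functional assay on MCF7 cells (Homo sapiens) for inhibition, read by MTT assay, with a stated time of 72 h; a higher number here means a weaker inhibitor, a lower number a stronger inhibitor. Compound 1 `O=C(Nc1ccccc1[N+](=O)[O-])c1ccc(/N=N\c2c[nH]c3ccccc23)cc1` gives 101000 nM, compound 2 `Cc1ccc(NC(=O)c2ccc(/N=N\c3c[nH]c4ccccc34)cc2)c(C)c1` gives 87000 nM, and compound 3 `O=C(Nc1cccc(Cl)c1)c1ccc(/N=N\c2c[nH]c3ccccc23)cc1` gives 82700 nM; the number for compound 2 lies within the scatter of both others, so the three cannot be told apart. Compound 4 `O=C(Nc1ccc(Cl)cc1)c1ccc(/N=N\c2c[nH]c3ccccc23)cc1` differs from compound 2 by 4-chlorophenyl in place of 2,4-dimethylphenyl on an amide-type nitrogen. The closest comparison is a 1.1-fold lower number from compound 2 to compound 3 (0.02 log units; within the scatter), which placed 3-chlorophenyl at the same spot; the moves a 1.2-fold lower number from compound 1 to compound 2 (0.06 log units; within the scatter) and a 1.2-fold lower number from compound 1 to compound 3 (0.09 log units; within the scatter) were similarly small. No shift beyond the scatter is therefore expected for compound 4, and the expected step is a 1.0-fold lower number from compound 2 to compound 4 (0.01 log units; within the scatter). Compound 4 is estimated at 85000 nM, with a range from 42000 nM to 170000 nM.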

Compound 4, half-maximal inhibitory concentration: 107000 nM
Compound 4: the middle estimate sits 1.3-fold (0.10 log units) below what was measured, and the stated range covers the measured number.
By their numbers in this assay, from the lowest: compounds 3, 2, 1 and 4 (each within the scatter of the next).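

In this assay, 4-chlorophenyl on the amide-type nitrogen cannot be told apart from any of the earlier groups: the steps (a 1.2-fold higher number from compound 2 to compound 4 (0.09 log units; within the scatter)), (a 1.3-fold higher number from compound 3 to compound 4 (0.11 log units; within the scatter)) and (a 1.1-fold higher number from compound 1 to compound 4 (0.03 log units; within the scatter)) all stay within the scatter. Among these compounds, then, 3-chlorophenyl and 4-chlorophenyl give no readable difference, so all four substituted phenyl groups remain level. No other measurement here offers an explanation for this. Still open, going by these compounds, is what an amine or carboxylic acid on this phenyl ring, or a longer chain in place of the ring, would do.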